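The source may report more compounds than this note shows. Statements on the series, on what has been measured and on what is new or still open speak of the compounds shown alone.

Measured compounds in an assay for inhibition of acid-sensing ion channel 3 (Homo sapiens), read by patch clamp, tested at 1 uM; on this read-out lower numbers stand for less inhibition and higher numbers for more inhibition at the one concentration tested (going by the name of the read-out):

- compound 1, `CCCNc1nc(N)c(C(=O)N=C(N)N)nc1Cl`: 24%
- compound 2, `NC(N)=NC(=O)c1nc(Cl)c(NCc2cccc(F)c2)nc1N`: 29%
- compound 3, `NC(N)=NC(=O)c1nc(Cl)c(NCC2CCCCC2)nc1N`: 28%

Compound 3 stands second highest of the three numbers, but the three values sit close together: the step of a number 1 percentage points lower from compound 2 to compound 3 (within the scatter) and the step of a number 4 percentage points higher from compound 1 to compound 3 (within the scatter) are both within the scatter, so no order among compounds 1, 2 and 3 can be read from this assay.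

Compound 4, `NC(N)=NC(=O)c1nc(Cl)c(NCc2ccccc2F)nc1N`, is unmeasured. Its change from compound 3 is 2-fluorophenyl in place of cyclohexyl on a saturated chain carbon bound to a nitrogen on an aromatic ring.

The step that bears most directly is a number 1 percentage points lower from compound 2 to compound 3 (within the scatter), in which a fluorophenyl on the saturated chain carbon and a cyclohexyl gave indistinguishable numbers. The step of a number 5 percentage points higher from compound 1 to compound 2 (within the scatter), where a fluorophenyl enters in place of ethyl, is likewise within the scatter. Nothing in these three compounds separates a fluorine on one position of the phenyl from another, so for compound 4 a step of no change at the digits printed from compound 3 to compound 4 (within the scatter) is expected, which is none beyond the scatter. Compound 4 is estimated at 28%, between 16% and 40%.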

Compound 4, a percentage reported as inhibition, at one concentration (the size of the read-out at that concentration, not a potency): 26%
For compound 4 the middle estimate is 2 percentage points above the measured one, and the stated range covers the measured number.
By their numbers in this assay, from the lowest: compounds 1, 4, 3 and 2 (each within the scatter of the next).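

In this assay, the 2-fluorophenyl joins ethyl, 3-fluorophenyl and cyclohexyl on the saturated chain carbon bound to a nitrogen on an aromatic ring, and it cannot be told from any of them: the result is a number 2 percentage points lower from compound 3 to compound 4 (within the scatter) and a number 2 percentage points higher from compound 1 to compound 4 (within the scatter) as well. Among the compounds shown here, the new compound also gives the first comparison of two fluorophenyl groups at this place, with a number 3 percentage points lower from compound 2 to compound 4 (within the scatter) and thus no separation between them at the one concentration tested. Nothing measured here offers an explanation for these small steps.

On these data alone, whether any group at this place can move the number beyond the scatter remains open, and a primary amine, a carboxylic acid or a longer alkyl chain on that carbon would be informative. These single-concentration numbers also leave the potency of all four compounds undefined.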